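The source may hold more compounds than are shown below. What is called first, only, known or untested is meant among the compounds shown, and "the series" means these compounds.

Within the data shown here, compound 2 `CSc1cccc(N2CCN(Cc3nc[nH]c3C)C2=O)c1` stands highest of the two numbers so far in a functional assay (Cavia porcellus) for antagonist activity at Serotonin 3 (5-HT3) receptor (Homo sapiens) (a higher number here means a weaker inhibitor, a lower number a stronger inhibitor), where compound 2 gives 120 nM; compound 1 `Cc1[nH]cnc1CN1CCN(c2cccc(Cl)c2)C1=O` gives 12 nM. Among the measured compounds shown here, the only measured step, a 10-fold higher number from compound 1 to compound 2 (1.00 log units; beyond the scatter), shows that exchanging the group on the aromatic carbon moves the number well beyond the scatter. Compound 3 `COc1cccc(N2CCN(Cc3nc[nH]c3C)C2=O)c1` carries methoxy in place of methylsulfanyl on an aromatic carbon. For the measured compounds named here, no measured step involves methoxy, so that step bears only loosely on the change. A small step toward a lower number, a 2.4-fold lower number from compound 2 to compound 3 (0.38 log units; beyond the scatter), is expected, and compound 3 is estimated at 50 nM, within 15 nM to 200 nM.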

Compound 3, antagonist equilibrium constant: 67.8 nM
Beside the measured number, compound 3's estimate is 1.4-fold (0.13 log units) below it; the measured number falls inside the stated range.
By their numbers in this assay, from the lowest: compound 1; then compounds 3 and 2 (each within the scatter of the next).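

In this assay the exchange on this aromatic carbon gives a 1.8-fold lower number from compound 2 to compound 3 (0.25 log units; within the scatter) and so leaves methoxy and methylsulfanyl indistinguishable here, whereas the earlier compounds had shown only that methylsulfanyl differs from chloro. Methoxy also separates from chloro, with a 5.7-fold higher number from compound 1 to compound 3 (0.75 log units; beyond the scatter) and thus both groups give higher numbers than chloro. Nothing available explains why chloro stands apart from the other two groups. From the compounds shown here alone, whether bromo, fluoro or an amine on this carbon would match chloro or join methoxy and methylsulfanyl remains open.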